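The source may hold more compounds than are shown below. What is called first, only, known or untested is meant among the compounds shown, and "the series" means these compounds.

Compound 2 `COc1ccc(/C=C\C(=O)O)c(OCc2cn(-c3ccccc3)nn2)c1CC=C(C)C` is one of two measured compounds in a functional assay on PC-3 cells (Homo sapiens) for cytotoxicity, read by MTT assay, with a stated time of 24 h (on this read-out higher numbers stand for weaker inhibition and lower numbers for stronger inhibition), where compound 2 gives 35000 nM. The other is compound 1 `COc1ccc(/C=C\C(=O)O)c(OCc2cn(-c3ccccc3F)nn2)c1CC=C(C)C`, which in this assay gives 24200 nM. Among the compounds with values here, the only step between them, a 1.4-fold higher number from compound 1 to compound 2 (0.16 log units; within the scatter), lies within the scatter, so the two numbers cannot be ranked against each other and compound 2 cannot be called the weaker of the pair.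

Compound 3 `COc1ccc(/C=C\C(=O)O)c(OCc2cn(-c3ccccc3C(=O)N3CCC(O)C3)nn2)c1CC=C(C)C` differs from compound 2 by (3-hydroxypyrrolidin-1-yl)carbonyl in place of hydrogen on an aromatic carbon. Within the data shown here, no measured step bears directly on this change: the single step on record, a 1.4-fold higher number from compound 1 to compound 2 (0.16 log units; within the scatter), swapped one small atom for another on the same ring and left the read-out within the scatter, whereas the new group is much larger and brings a ring with a hydrogen-bond donor. With nothing to anchor a shift in either direction, the expected step is none beyond the scatter, so for compound 3 the estimated step is a 1.2-fold lower number from compound 2 to compound 3 (0.07 log units; within the scatter) with wide uncertainty. Compound 3 is therefore expected to give about 30000 nM, within a range from 8000 nM to 110000 nM.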

Compound 3, half-maximal inhibitory concentration: 36200 nM
For compound 3 the middle estimate is 1.2-fold (0.08 log units) below the measured one; measured number inside the range.
By their numbers in this assay, from the lowest: compounds 1, 2 and 3 (each within the scatter of the next).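

In this assay, (3-hydroxypyrrolidin-1-yl)carbonyl in place of hydrogen gives a 1.0-fold higher number from compound 2 to compound 3 (0.01 log units; within the scatter) and in place of fluoro gives a 1.5-fold higher number from compound 1 to compound 3 (0.17 log units; within the scatter) so compounds 1, 2 and 3 cannot be told apart on this read-out. The earlier pair covered only an exchange between a hydrogen atom and a fluoro group, whereas this result extends the picture to a group of 8 heavy atoms, with a five-membered non-aromatic ring and a hydrogen-bond donor, on the same aromatic carbon, ortho to a large group, still without a step beyond the scatter. No measurement at hand explains why the read-out stays within the scatter across such different groups.

The compounds shown leave open whether an aminomethyl group or a longer alkyl chain on this aromatic carbon would give a step beyond the scatter. They also leave open whether the hydroxyl of the new group matters, a question that the plain pyrrolidin-1-ylcarbonyl group, without that hydroxyl, could address directly.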